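The source may report more compounds than this note shows. Statements on the series, on what has been measured and on what is new or still open speak of the compounds shown alone.

In a functional assay on FM3A cells (Mus musculus) for antiproliferative activity, with a stated time of 48 h (a higher number here means a weaker inhibitor, a lower number a stronger inhibitor), compound 1 `C=C(Br)C(=O)Nc1ccc(/C=C/C(=O)c2ccc(Cl)cc2)cc1` gives 1300 nM and compound 2 `C=C(Br)C(=O)Nc1ccc(/C=C/C(=O)c2ccc(OC)cc2)cc1` gives 1200 nM, two values within the scatter of each other. At the top stands compound 3 `C=C(Br)C(=O)Nc1ccc(/C=C/C(=O)c2cccc(OC)c2)cc1` with 2700 nM, the highest of the three numbers. Compound 4 `C=C(Br)C(=O)Nc1ccc(/C=C/C(=O)c2cccs2)cc1` has thiophen-2-yl in place of 3-methoxyphenyl on a carbonyl carbon. Two measured changes at this place bear on it, a 2.1-fold higher number from compound 1 to compound 3 (0.32 log units; beyond the scatter) and a 2.3-fold higher number from compound 2 to compound 3 (0.35 log units; beyond the scatter), both modest and both leaving compound 3 with the higher number. Going by the values given here, no thiophen-2-yl compound has been measured, so the direction remains uncertain. In this assay a modest move back towards the other two values is expected, a 1.7-fold lower number from compound 3 to compound 4 (0.23 log units; within the scatter). The estimate for compound 4 is 1600 nM, with an expected range from 650 nM to 3800 nM.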

Compound 4, half-maximal inhibitory concentration: 520 nM
For compound 4 the middle estimate is 3.1-fold (0.49 log units) above the measured one; the whole stated range lies above it.
By their numbers in this assay, from the lowest: compound 4; then compounds 2 and 1 (each within the scatter of the next); then compound 3.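

In this assay the five-membered thiophen-2-yl on the carbonyl carbon gives the lowest number of the four compounds, with a 5.2-fold lower number from compound 3 to compound 4 (0.72 log units; beyond the scatter) and a 2.3-fold lower number from compound 2 to compound 4 (0.36 log units; beyond the scatter) and also a 2.5-fold lower number from compound 1 to compound 4 (0.40 log units; beyond the scatter). Going by these compounds alone, this place therefore admits more than the six-membered carbon rings of the earlier compounds, and a ring with a hetero atom goes below all of them. Nothing measured here accounts for this change.

Ring size and hetero atom change together in compound 4, and the compounds shown do not separate them. As far as these compounds go, whether furan-2-yl or pyridin-3-yl at this carbon would give a similarly low number remains open.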